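Working notes on the shared core: compound 2 to compound 4

The source may report more compounds than this note shows. Statements on the series, on what has been measured and on what is new or still open speak of the compounds shown alone.

Measured so far in a functional assay on HL-60 cells (Homo sapiens) for antiproliferative activity, with a stated time of 24 h; on this read-out higher numbers stand for weaker inhibition and lower numbers for stronger inhibition:
- compound 1 `NC(=O)c1c(NC(=O)c2ccccc2C(F)(F)F)sc2c1CCN(C(=S)Nc1ccccc1Cl)C2`: 17600 nM
- compound 2 `NC(=O)c1c(NC(=O)c2ccccc2F)sc2c1CCN(C(=S)Nc1cc(C(F)(F)F)cc(C(F)(F)F)c1)C2`: 17900 nM
- compound 3 `NC(=O)c1c(NC(=O)c2ccccc2I)sc2c1CCN(C(=S)Nc1ccccc1Br)C2`: 18900 nM

Compound 2 sits second highest of the three numbers in this assay, with compound 1 nearest and compound 3 furthest; both gaps lie within the scatter, so the three compounds cannot be told apart on this read-out. For the measured compounds named here, no pair among them differs in only one place, so no single step is known.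

Compound 4 `Cc1ccc(C(=O)Nc2sc3c(c2C(N)=O)CCN(C(=S)Nc2cc(C(F)(F)F)cc(C(F)(F)F)c2)C3)cc1` is not yet measured. Its difference from compound 2 is 4-methylphenyl in place of 2-fluorophenyl on a carbonyl carbon. The rest of the molecule, including the thiourea-linked 3,5-bis(trifluoromethyl)phenyl part, is unchanged from compound 2.

The measured compounds vary the acyl aryl group across three different substituents without any difference beyond the scatter, so for compound 4 a step in this assay of no size beyond the scatter is expected, in no particular direction. The estimate for compound 4 in this assay is 18000 nM, within a range of 9000 nM to 36000 nM, which means an expected step of a 1.0-fold higher number from compound 2 to compound 4 (0.00 log units; within the scatter).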

Compound 4, half-maximal inhibitory concentration: 11800 nM
Compound 4: middle estimate off by 1.5-fold (0.18 log units), on the high side; the measured number falls inside the stated range.
By their numbers in this assay, from the lowest: compounds 4, 1, 2 and 3 (each within the scatter of the next).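

In this assay, the series now has its first step that changes one place only: a 1.5-fold lower number from compound 2 to compound 4 (0.18 log units; within the scatter), with 4-methylphenyl in place of 2-fluorophenyl on a carbonyl carbon and the rest of the molecule unchanged. For the compounds shown here, this exchange of aryl groups therefore leaves the number within the scatter, which the earlier compounds could not show because each of them also differed in a second place. No available data bear on the reason for the size of this step.

The step changes the substituent and its ring position together, so an unsubstituted phenyl group would be needed to separate the contributions of fluorine and methyl. Going by these compounds, whether this position stays as flat with a carboxylic acid, an amine or a cyclohexyl group remains open.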